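The source may hold more compounds than are shown below. What is called first, only, known or untested is meant among the compounds shown, and "the series" means these compounds.

Working notes on the series.

Compound 1 `Cc1ccc(NC(=O)C(=O)NC(c2nc(C)c(CCO)s2)C2CCCCN2)cc1F` is the reference point. For the measured compounds named here, in an ADME assay on MT2 cells (Homo sapiens) for cytotoxicity, read by XTT assay, with a stated time of 4 days (a higher number here means that more compound is tolerated, a lower number that less compound is tolerated), compound 1 gives 85000 nM, the only number that stands as a number here. Compound 2 `Cc1ccc(NC(=O)C(=O)NC(c2nc(C)c(CO)s2)C2CCCCN2)cc1F` is read in this assay at > 88000 nM, which is a limit of the assay, that is the limit of > 88000 nM in this assay, at which 1 of the 3 values shown sits. Compound 3 `CC(=O)N1CCCCC1C(NC(=O)C(=O)Nc1ccc(Cl)cc1)c1nc(C)c(CCO)s1` is read in this assay at > 84000 nM, also a limit of the assay, namely (the limit of > 84000 nM in this assay, at which 1 of the 3 values shown sits). Going by the values given here, the only measured step, an at least 1.0-fold higher number from compound 1 to compound 2 (0.01 log units; that floor lies within the scatter), concerns hydroxy in place of hydroxymethyl on the side chain and its floor sits within the scatter; it says nothing about a change on the aromatic ring.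

Compound 4 `Cc1nc(C(NC(=O)C(=O)Nc2ccc(F)c(F)c2)C2CCCCN2)sc1CCO` is the next compound to be measured in this assay. It differs from compound 1 by fluoro in place of methyl on an aromatic carbon. Among the compounds with values here, no measured step touches the aromatic ring of carbon only, so the step of no change at the digits printed from compound 1 to compound 4 (within the scatter) is expected to stay within the scatter, with no direction. Compound 4 is therefore estimated at 85000 nM, with a range from 45000 nM to 160000 nM.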

Compound 4, half-maximal cytotoxic concentration: > 78200 nM
Compound 4: no number, only a limit (the forecaster's own chance of this, stated with the estimate: 50%); the middle value is on the limit's open side.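

Compound 4 stands in this assay at > 78200 nM, a limit of the assay and not a number. For the compounds shown here, no new step can therefore be read between compound 1 and compound 4. The compounds shown leave open whether fluoro in place of methyl on the aromatic carbon changes the tolerated concentration at all, and in which direction.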